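A furan-2-yl swap on the carbonyl carbon

The compounds below may be only part of what the source reports. "The series", "measured", "known", "first", "only" and "open" are said of these compounds alone.

Compound 1 `CC(=O)O[C@H]1CC[C@]2(C)[C@H](CC[C@@](C)(O)[C@H]2CC[C@@H]2C(C)=CC[C@H]3[C@H](CC[C@]3(C)O)C2(C)C)OC1(C)C` gives 38000 nM
Compound 2 `CC1=CC[C@H]2[C@H](CC[C@]2(C)O)C(C)(C)[C@@H]1CC[C@H]1[C@]2(C)CC[C@H](OC(=O)c3ccc(C)cc3)C(C)(C)O[C@H]2CC[C@@]1(C)O` gives 33400 nM
Compound 3 `CC1=CC[C@H]2[C@H](CC[C@]2(C)O)C(C)(C)[C@@H]1CC[C@H]1[C@]2(C)CC[C@H](OC(=O)c3cccc(C(F)(F)F)c3)C(C)(C)O[C@H]2CC[C@@]1(C)O` gives 36300 nM

These three numbers come from a functional assay on MDA-MB-231 cells (Homo sapiens) for antiproliferative activity, read by MTT assay, with a stated time of 72 h; on this read-out higher numbers stand for weaker inhibition and lower numbers for stronger inhibition. Compound 3 shows no separation from the other two, since a 1.0-fold lower number from compound 1 to compound 3 (0.02 log units; within the scatter) and a 1.1-fold higher number from compound 2 to compound 3 (0.04 log units; within the scatter) both lie within the scatter.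

Compound 4 `CC1=CC[C@H]2[C@H](CC[C@]2(C)O)C(C)(C)[C@@H]1CC[C@H]1[C@]2(C)CC[C@H](OC(=O)c3ccco3)C(C)(C)O[C@H]2CC[C@@]1(C)O` has not yet been measured. It differs from compound 3 at one place: furan-2-yl in place of 3-(trifluoromethyl)phenyl on a carbonyl carbon. In words, furan-2-yl stands in place of 3-(trifluoromethyl)phenyl on a carbonyl carbon.

All three measured steps change the group at this same place. Besides the two above, there is a 1.1-fold lower number from compound 1 to compound 2 (0.06 log units; within the scatter), and it too lies within the scatter. Methyl, 4-methylphenyl and 3-(trifluoromethyl)phenyl therefore give numbers that cannot be told apart. Among the measured compounds shown here, none of the measured compounds carries furan-2-yl, so that group remains untested, and the expectation rests on these three compounds alone. No step beyond the scatter is expected in this assay. The expected size of the change is a 1.0-fold lower number from compound 3 to compound 4 (0.02 log units; within the scatter). Compound 4 is estimated at 35000 nM, with an expected range of 20000 nM to 60000 nM.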

Compound 4, half-maximal inhibitory concentration: 14000 nM
Compound 4: middle estimate off by 2.5-fold (0.40 log units), on the high side; the measured number lies below the stated range.
By their numbers in this assay, from the lowest: compound 4; then compounds 2, 3 and 1 (each within the scatter of the next).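

In this assay, the group on the carbonyl carbon proved able to move the number after all: furan-2-yl gives a 2.6-fold lower number from compound 3 to compound 4 (0.41 log units; beyond the scatter), a 2.4-fold lower number from compound 2 to compound 4 (0.38 log units; beyond the scatter) and a 2.7-fold lower number from compound 1 to compound 4 (0.43 log units; beyond the scatter), all modest, whereas methyl, 4-methylphenyl and 3-(trifluoromethyl)phenyl could not be told apart. Compound 4 is therefore the only one of the four with steps to all the others beyond the scatter, and it is the most potent of them here, although compound 4 still reads 14000 nM. The swap from compound 3 replaces a six-membered aromatic ring of carbon only with a five-membered aromatic ring with one hetero atom and adds one hydrogen-bond acceptor, but no measurement at hand explains why the number falls.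

As far as these compounds go, it remains open whether the step depends on the ring oxygen or on the five-membered aromatic ring itself, which a thiophen-2-yl or pyrrol-2-yl group on the same carbonyl carbon could separate. Also open, from the compounds shown here alone, is whether the gain survives with a furan-3-yl group, or with an amine in place of the oxygen next to the carbonyl group.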